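The compounds below may be only part of what the source reports. "The series", "measured", "known", "first", "only" and "open" are said of these compounds alone.

Measured compounds:
compound 1, `O=C(CCc1nc2cccnc2n1Cc1ccccc1)NCc1ccc(F)cc1`, 41.2 mL/min
compound 2, `O=C(CCc1nc2cccnc2n1Cc1ccccc1)NCC1CCCCC1`, 17.4 mL/min

In an ADME assay on liver (Homo sapiens) for metabolic stability, read by HPLC, using microsomes and NADPH, with a stated time of 45 min, tested at 1 uM (on this read-out higher numbers stand for fast clearance and lower numbers for slow clearance), compound 2 stands lowest of the two numbers available, its nearest neighbour being compound 1 with 41.2 mL/min. Going by the values given here, the only step measured so far is a 2.4-fold lower number from compound 1 to compound 2 (0.37 log units; beyond the scatter); it shows that swapping an aromatic group for a saturated ring on the same chain carbon brought the number down.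

Compound 3, `C[C@H](NC(=O)CCc1nc2cccnc2n1Cc1ccccc1)c1ccccc1`, is not yet measured. It differs from compound 2 as follows: 1-phenylethyl in place of cyclohexylmethyl on an amide-type nitrogen. The change runs back toward an aromatic group on the amide-type nitrogen, the direction opposite to the measured step. Since that step was a 2.4-fold lower number from compound 1 to compound 2 (0.37 log units; beyond the scatter), a rise of similar size is expected for compound 3 in this assay, with the expected step being a 2.0-fold higher number from compound 2 to compound 3 (0.30 log units; within the scatter). Compound 3 is therefore estimated at 35 mL/min, within a range of 18 mL/min to 70 mL/min.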

Compound 3, intrinsic clearance in a liver preparation (reported as CLH), per the amount of preparation that the assay uses: 62 mL/min
Estimate against measurement, compound 3: 1.8-fold (0.25 log units) below; the measured number falls inside the stated range.
By their numbers in this assay, from the lowest: compound 2; then compounds 1 and 3 (each within the scatter of the next).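

In this assay, the saturated ring of compound 2 now stands apart from a second aromatic group, not only from 4-fluorobenzyl: putting in 1-phenylethyl for cyclohexylmethyl on the amide-type nitrogen gives a clear rise (a 3.6-fold higher number from compound 2 to compound 3 (0.55 log units; beyond the scatter)). The two aromatic groups are not told apart, since 1-phenylethyl in place of 4-fluorobenzyl gives a step within the scatter (a 1.5-fold higher number from compound 1 to compound 3 (0.18 log units; within the scatter)), so among these three compounds the low number belongs to compound 2 alone, with none going against that. Nothing given here explains the gap.

The compounds shown leave open where a plain benzyl group or the mirror-image form of 1-phenylethyl would fall. They also leave open whether a longer chain to the cyclohexyl ring, or an amine on that ring, would keep the number low.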